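The source may report more compounds than this note shows. Statements on the series, on what has been measured and on what is new or still open speak of the compounds shown alone.

Notes on the series: in a functional assay on HCT-116 cells (Homo sapiens) for cytotoxicity, read by scintillation counting and thymidine incorporation, with a stated time of 72 h (a lower number here means a stronger inhibitor, a higher number a weaker inhibitor), compound 2 `COc1cc(OC)cc(C(=CC#N)c2ccc(OC)c(OC)c2)c1` gives 18 nM, the only true number so far. Compound 1 `C=C(c1cc(OC)cc(OC)c1)c1ccc(OC)c(OC)c1` reads > 10000 nM, which is a limit of the assay and not a number. For the measured compounds named here, the sole measured step is therefore open-ended, as the limit of > 10000 nM in this assay, at which 1 of the 2 values shown sits, shows: an at least 550-fold lower number from compound 1 to compound 2 (2.74 log units; beyond the scatter).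

Compound 3 `CC=C(c1cc(OC)cc(OC)c1)c1ccc(OC)c(OC)c1` is the next to be read, and it carries methyl in place of cyano on a double-bonded chain carbon bound to a double-bonded chain carbon. This change also removes the cyano of compound 2, so the step seen with compound 1 is the one that bears on it. Going by the values given here, that step swapped hydrogen for cyano, however, and no measured compound yet carries methyl at this place. A large move towards a higher number in this assay is expected, possibly short of the full size of the earlier step. The estimated change is an 83-fold higher number from compound 2 to compound 3 (1.92 log units; beyond the scatter). For compound 3 the expected value is 1500 nM, with an estimated range of 100 nM to 10000 nM.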

Compound 3, half-maximal inhibitory concentration: 480 nM
For compound 3 the middle estimate is 3.1-fold (0.49 log units) above the measured one; measured number inside the range.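

In this assay the place on a double-bonded chain carbon bound to a double-bonded chain carbon now has three substituents read, so the picture is no longer a bare contrast between cyano and hydrogen. Cyano is not the only group that gives a measurable number here, since methyl in place of hydrogen gives an at least 20-fold lower number from compound 1 to compound 3 (1.31 log units; beyond the scatter), yet methyl does not match cyano, as shown by a 27-fold higher number from compound 2 to compound 3 (1.43 log units; beyond the scatter). Going by these compounds, both comparisons with hydrogen stay open-ended, compound 1 reading > 10000 nM, which is a limit and not a number: the limit of > 10000 nM in this assay, at which 1 of the 3 values shown sits.

Only hydrogen, methyl and cyano are shown at this place, so it remains open how an ethyl, a chloro, a carboxamide or an aminomethyl group would read there, and whether cyano would still lead over all of them. On these data alone, the methoxy groups of the shared core are the same in all three compounds, so it is also open whether the gap between compound 2 and compound 3 would hold with a hydroxyl in place of one of them.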